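From hydroxy to benzoyloxy: a step without precedent

A few compounds are considered here, and "the series" means these few. Any claim that something is new, unique, unknown or untested is made for them only; others in the source may bear on it.

The study rests on three measured compounds. In a functional assay on MCF7 cells (Homo sapiens) for antiproliferative activity, read by MTT assay, with a stated time of 48 h (a lower number here means a stronger inhibitor, a higher number a weaker inhibitor), compound 1 `Cc1ccc(-c2nc3ccc(Cl)cc3c(=O)[nH]2)cc1` gives 4.98 ug/mL. Compound 2 `Cc1ccc(-c2nc3ccc(Cl)cc3c(=S)[nH]2)cc1` gives 3.35 ug/mL in this assay. Compound 3 `Cc1ccc(-c2nc(NO)c3cc(Cl)ccc3n2)cc1` gives 6.81 ug/mL in this assay, the highest of the three numbers; its distance from compound 1 lies within the scatter, whereas compound 2 sits beyond the scatter below it.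

Compound 4 `Cc1ccc(-c2nc(NOC(=O)c3ccccc3)c3cc(Cl)ccc3n2)cc1` is not yet measured. It differs from compound 3 by benzoyl in place of hydrogen on an oxygen. Among the compounds with values here, no pair among the measured compounds shares this change, so the numbers at hand give no guide to its size or direction. In this assay the expected step is a 1.2-fold lower number from compound 3 to compound 4 (0.09 log units; within the scatter), judged small and without a firm direction, most likely within the scatter. Compound 4 is accordingly estimated at 5.5 ug/mL, with a range from 2.2 ug/mL to 14 ug/mL reflecting the lack of any comparable change in this small set.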

Compound 4, half-maximal inhibitory concentration: 5.59 ug/mL
Beside the measured number, compound 4's estimate is 1.0-fold (0.01 log units) below it; the measured number falls inside the stated range.
By their numbers in this assay, from the lowest: compounds 2, 1, 4 and 3 (each within the scatter of the next, the first and the last beyond it).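

In this assay the change from hydroxy to benzoyloxy gives a 1.2-fold lower number from compound 3 to compound 4 (0.09 log units; within the scatter) and so leaves the number within the usual scatter. Within the data shown here, this is the first reading of any change at this site, an oxygen on a nitrogen on an aromatic ring, and it shows that benzoyl, with its six-membered aromatic ring, can take the place of hydrogen there without a clear shift in antiproliferative activity. No supporting measurement bears on why the number holds so steady.

A single step cannot show whether this holds for other groups on the same oxygen, such as acetyl, methyl or a longer acyl chain. Nor can it show whether a benzoyl carrying a nitro group or a methoxy group on its ring would give a similar number.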